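Aryl and alkynyl replacements at the core, microsomal clearance

A few compounds are considered here, and "the series" means these few. Any claim that something is new, unique, unknown or untested is made for them only; others in the source may bear on it.

Measured compounds in an ADME assay (liver) for metabolic stability, with Liver microsome (Homo sapiens) as the target, using microsomes and NADPH, with a stated time of 30 min, tested at 1 uM; a higher number here means faster removal of the compound, a lower number slower removal:
compound 1 `Nc1ccc(S(=O)(=O)N2CCN(c3ncc(C(O)(C(F)(F)F)C(F)(F)F)cc3C#CCCO)CC2)cn1` gives < 14 mL.min-1.g-1, a limit of the assay rather than a number
compound 2 `CS(=O)(=O)c1ccc(-c2cc(C(O)(C(F)(F)F)C(F)(F)F)cnc2N2CCN(S(=O)(=O)c3ccc(N)nc3)CC2)cc1` gives 32 mL.min-1.g-1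
compound 3 `Nc1ccc(S(=O)(=O)N2CCN(c3ncc(C(O)(C(F)(F)F)C(F)(F)F)cc3-c3ccncc3)CC2)cn1` gives 15 mL.min-1.g-1

Compound 1 sits at the floor of this assay, so only a ceiling is known for it (the limit of < 14 mL.min-1.g-1 in this assay, at which 1 of the 3 values shown sits). Compound 4 `Nc1ccc(S(=O)(=O)N2CCN(c3ncc(C(O)(C(F)(F)F)C(F)(F)F)cc3-c3cccnc3)CC2)cn1` differs from compound 1 in one place: pyridin-3-yl in place of 4-hydroxybut-1-yn-1-yl on an aromatic carbon. Two measured steps leave from the same starting compound. One gave an at least 2.2-fold higher number from compound 1 to compound 2 (0.35 log units; beyond the scatter); the other, with a ring much like the incoming one, gave an at least 1.0-fold higher number from compound 1 to compound 3 (0.02 log units; that floor lies within the scatter). Between the two aryl groups there was a 2.1-fold lower number from compound 2 to compound 3 (0.33 log units; beyond the scatter). Compound 4 is expected to land near compound 3, so an at least 1.2-fold higher number from compound 1 to compound 4 (0.08 log units; that floor lies within the scatter) is expected, a step that may well lie within the scatter. Compound 4 is estimated at 17 mL.min-1.g-1, within 9 mL.min-1.g-1 to 34 mL.min-1.g-1.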

Compound 4, intrinsic clearance in microsomes: 17 mL.min-1.g-1
For compound 4 middle estimate and measured number coincide at the digits printed; the measured number falls inside the stated range.
By their numbers in this assay, from the lowest: compounds 3, 4 and 2 (each within the scatter of the next, the first and the last beyond it). At a limit, below all of these: compound 1.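

In this assay, pyridin-3-yl in place of pyridin-4-yl gives a 1.1-fold higher number from compound 3 to compound 4 (0.05 log units; within the scatter). Pyridin-3-yl in place of 4-(methylsulfonyl)phenyl gives a 1.9-fold lower number from compound 2 to compound 4 (0.27 log units; within the scatter), so, unlike the pyridin-4-yl step, this one does not clear the scatter. Pyridin-3-yl in place of 4-hydroxybut-1-yn-1-yl gives an at least 1.2-fold higher number from compound 1 to compound 4 (0.08 log units; that floor lies within the scatter). Compound 1 carries a limit rather than a number, so this step is known only as a floor.

Open, as far as these compounds go, is where a pyridin-2-yl ring would fall in this assay. Also open, from the compounds shown here alone, is how an amine or a carboxylic acid at the end of the alkynyl chain would compare.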